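A Methyl Moved onto the Fused Ring of Compound 1

The source may hold more compounds than are shown below. What is called first, only, known or untested is meant among the compounds shown, and "the series" means these compounds.

compound 1 `CCOC(=O)c1c(-c2c(Cl)c3ccccc3oc2=O)nn(-c2ccccc2)c1C(=O)OCC` — 100000 nM
compound 2 `CCOC(=O)c1c(-c2c(Cl)c3ccccc3oc2=O)nn(-c2cccc(C)c2)c1C(=O)OCC` — 30000 nM
compound 3 `CCOC(=O)c1c(-c2c(Cl)c3ccccc3oc2=O)nn(-c2ccc(Br)cc2)c1C(=O)OCC` — 500000 nM

In a functional assay on HeLa cells (Homo sapiens) for cytotoxicity, read by MTT assay, with a stated time of 48 h (on this read-out lower numbers stand for stronger inhibition and higher numbers for weaker inhibition), compound 1 stands second highest of the three numbers: compound 2 sits lower, a 3.3-fold lower number from compound 1 to compound 2 (0.52 log units; beyond the scatter), and compound 3 sits higher, a 5.0-fold higher number from compound 1 to compound 3 (0.70 log units; beyond the scatter). Compound 4 `CCOC(=O)c1c(-c2c(Cl)c3cc(C)ccc3oc2=O)nn(-c2ccccc2)c1C(=O)OCC` differs from compound 1 by a single change: methyl in place of hydrogen on an aromatic carbon. The methyl step, a 3.3-fold lower number from compound 1 to compound 2 (0.52 log units; beyond the scatter), bears most on this, a modest lowering, while the bromo step, a 5.0-fold higher number from compound 1 to compound 3 (0.70 log units; beyond the scatter), went the other way and is larger. On these data alone, a methyl at this new place is untested, so the expected step is small and toward a lower number, a 2.0-fold lower number from compound 1 to compound 4 (0.30 log units; within the scatter). Compound 4 is therefore estimated at 50000 nM, with a range from 15000 nM to 200000 nM.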

Compound 4, half-maximal inhibitory concentration: 228000 nM
For compound 4 the middle estimate is 4.6-fold (0.66 log units) below the measured one; measured number above the stated range.
By their numbers in this assay, from the lowest: compound 2; then compound 1; then compound 4; then compound 3.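

The same small swap of methyl for hydrogen now pushes the number the other way, with a 2.3-fold higher number from compound 1 to compound 4 (0.36 log units; beyond the scatter) set against a 3.3-fold lower number from compound 1 to compound 2 (0.52 log units; beyond the scatter) for a methyl on the ring attached to the aromatic nitrogen. In this assay the effect of a methyl therefore depends on its place, and a gain on one ring does not carry over to the fused system of two rings. Nothing available explains this reversal.

Still open, on these data alone, is whether this place on the fused ring tolerates anything better than hydrogen. A methoxy group, an amine or a chlorine there could show whether any replacement lowers the number.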